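Swapping a sec-Butyl Ester for a Cyclohexyl Ester

A few compounds are considered here, and "the series" means these few. Any claim that something is new, unique, unknown or untested is made for them only; others in the source may bear on it.

Measured compounds:
compound 1 `CCSC(=O)C1=C(C)NC(=O)NC1c1ccco1`: 14%
compound 2 `CCC(C)OC(=O)C1=C(C)NC(=O)NC1c1ccco1`: 3%

In an assay on membranes from HeLa cells for displacement of a labelled ligand from adenosine receptor A3 (Homo sapiens), read by scintillation counting, with a stated time of 180 min, tested at 1 uM (on this read-out higher numbers stand for more inhibition at the one concentration tested (going by the name of the read-out) and lower numbers for less inhibition), compound 1 gives 14% and compound 2 gives 3%. Compound 2 stands lowest of the two numbers, with compound 1 the nearest, a higher value. Within the data shown here, the only measured step, a number 11 percentage points lower from compound 1 to compound 2 (beyond the scatter), concerns the group on the carbonyl carbon rather than the alkyl part of the ester, so it bears only loosely on the present change. Compound 3 `CC1=C(C(=O)OC2CCCCC2)C(c2ccco2)NC(=O)N1` differs from compound 2 by cyclohexyl in place of sec-butyl on an oxygen next to a carbonyl group. With no measured alkyl-for-alkyl swap to lean on, no step beyond the scatter is expected; compound 3 is estimated at 6% (range -5% to 20%), a step of a number 3 percentage points higher from compound 2 to compound 3 (within the scatter).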

Compound 3, a percentage reported as inhibition, at one concentration (the size of the read-out at that concentration, not a potency): 4%
Compound 3: middle estimate off by 2 percentage points, on the high side, within the range that was stated.
By their numbers in this assay, from the lowest: compounds 2, 3 and 1 (each within the scatter of the next, the first and the last beyond it).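

In this assay, cyclohexyl in place of sec-butyl on an oxygen next to a carbonyl group gives a number 1 percentage points higher from compound 2 to compound 3 (within the scatter), so this first alkyl-for-alkyl swap leaves the read-out unmoved beyond the scatter. Cyclohexyloxy in place of ethylsulfanyl on a carbonyl carbon gives a number 10 percentage points lower from compound 1 to compound 3 (within the scatter), so the step beyond the scatter seen with sec-butoxy is not repeated here. Nothing available explains these numbers. As far as these compounds go, whether a benzyl group or a longer chain in place of cyclohexyl would move the read-out remains open.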